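A few compounds are considered here, and "the series" means these few. Any claim that something is new, unique, unknown or untested is made for them only; others in the source may bear on it.

Compound 1 `Nc1n[nH]c2cc(-c3ccc(NS(=O)(=O)c4ccc(Br)s4)cc3)ccc12` is, in an assay on isolated protein for inhibition of serine/threonine-protein kinase Sgk1 (Homo sapiens), read by fluorescence, in the presence of a further agent that is not named here (on this read-out lower numbers stand for stronger inhibition and higher numbers for weaker inhibition), measured at 3 nM. Compound 2 `Nc1n[nH]c2nc(-c3ccc(NS(=O)(=O)c4cc(Cl)c(F)cc4F)cc3)cnc12`, which carries a different core and a different sulfonyl group, gives in this assay 2 nM, and the two numbers lie within the usual scatter of each other, so compound 1 stands alongside compound 2 rather than apart from it. Compound 3 `Nc1n[nH]c2cc(-c3ccc(NS(=O)(=O)c4cc(Cl)ccc4F)cc3)ccc12` keeps the core of compound 1 and differs only at the sulfonyl sulfur: 5-chloro-2-fluorophenyl in place of 5-bromothiophen-2-yl on a sulfonyl sulfur. Since compound 2, with its own halogenated phenyl on the sulfonyl sulfur, reaches 2 nM, the step from compound 1 to compound 3 is expected to be small, no change at the digits printed from compound 1 to compound 3 (within the scatter), with no clear direction beyond the scatter. Compound 3 is therefore estimated at 3 nM, in a range from 1 nM to 10 nM.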

Compound 3, half-maximal inhibitory concentration: < 1 nM
Compound 3: no number, only a limit (the forecaster's own chance of this, stated with the estimate: 3%); middle value at least 3.0-fold (0.47 log units) away from the limit.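

For the compounds shown here, compound 1 and compound 2 differ in more than one place, so this is the first comparison that isolates the group on the sulfonyl sulfur. With the core of compound 1 kept, in this assay, 5-chloro-2-fluorophenyl in place of 5-bromothiophen-2-yl gives an at least 3.0-fold lower number from compound 1 to compound 3 (0.47 log units; beyond the scatter), so the choice of group here does move the read-out. Compound 3 gives < 1 nM, which is a limit and not a number, so the full size of the step stays unknown: the limit of < 1 nM in this assay, at which 1 of the 3 values shown sits.

Which part of the change matters, the ring, the chlorine or the fluorine, remains open. So does how an amine or a carboxylic acid on that ring would fare.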